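Trimethoxyphenyl pyrazole chalcones: a methoxy addition series

A few compounds are considered here, and "the series" means these few. Any claim that something is new, unique, unknown or untested is made for them only; others in the source may bear on it.

Measured compounds in a functional assay on MDA-MB-231 cells (Homo sapiens) for inhibition, read by sulforhodamine B assay, with a stated time of 48 h; on this read-out higher numbers stand for weaker inhibition of growth and lower numbers for stronger inhibition of growth:
- compound 1, `COc1ccc(-c2cc(/C=C/C(=O)c3ccc(N)cc3)[nH]n2)cc1`, gives 2140 nM
- compound 2, `COc1ccc(C(=O)/C=C/c2cc(-c3cc(OC)c(OC)c(OC)c3)n[nH]2)cc1OC`, gives 1480 nM
- compound 3, `COc1ccc(-c2cc(/C=C/C(=O)c3ccc(N)cc3)[nH]n2)cc1OC`, gives 4420 nM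

Compound 2 carries the lowest of the three numbers; its value and that of compound 1 lie within the scatter of each other, so no order is drawn between them. The difference between the cores of compound 1 and compound 2 is not broken down here.

From compound 1 to compound 3 the change is methoxy in place of hydrogen on an aromatic carbon; this gives a 2.1-fold higher number from compound 1 to compound 3 (0.32 log units; beyond the scatter).

Compound 4, `COc1cc(C(=O)/C=C/c2cc(-c3cc(OC)c(OC)c(OC)c3)n[nH]2)cc(OC)c1OC`, is not yet measured. From compound 2 it differs by methoxy in place of hydrogen on an aromatic carbon. The surroundings differ from the earlier case in that the place is also meta to a methoxy group, so this is the same kind of change, not the same one.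

Beside the earlier step, the step from compound 2 to compound 4 is expected to be a 2.1-fold higher number from compound 2 to compound 4 (0.32 log units; beyond the scatter) in this assay, resting on a 2.1-fold higher number from compound 1 to compound 3 (0.32 log units; beyond the scatter) as the only precedent. Compound 4 is therefore estimated at 3100 nM, between 1500 nM and 7000 nM.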

Compound 4, concentration for 50% growth inhibition: 1520 nM
Compound 4: middle estimate off by 2.0-fold (0.31 log units), on the high side, and the stated range covers the measured number.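

In this assay, methoxy in place of hydrogen on an aromatic carbon gives a 1.0-fold higher number from compound 2 to compound 4 (0.01 log units; within the scatter). Set beside the earlier step, the change does not separate by core: the same change on two cores in this assay, a 2.1-fold higher number (0.32 log units; beyond the scatter) from compound 1 to compound 3 and a 1.0-fold higher number (0.01 log units; within the scatter) from compound 2 to compound 4, 2.0-fold (0.30 log units) apart, within the scatter of two such steps. This shows no dependence on the core, but it does not show that the step carries over at a fixed size, since one step lies beyond the scatter, the other lies within it, and two pairs are too few to settle the matter.

The compounds shown leave open how a hydroxyl group or a chlorine atom in place of that methoxy would read on either core. On these data alone, whether the methoxy step holds on a third core also stays open.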